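The compounds below may be only part of what the source reports. "The series", "measured", "known", "first", "only" and "open" are said of these compounds alone.

In a functional assay on DU-145 cells (Homo sapiens) for antiproliferative activity, read by MTT assay, with a stated time of 24 h (a lower number here means a stronger inhibitor, a higher number a weaker inhibitor), compound 1 `COc1ccc(-c2noc(-c3ccncc3)n2)cc1OC1CCCC1` gives > 1000000 nM as a limit, not a number. Compound 3 `COc1ccc(-c2noc(-c3cccnc3)n2)cc1OC1CCCC1` gives > 1000000 nM as a limit too. Compound 2 `COc1ccc(-c2noc(-c3ccc(F)cc3)n2)cc1OC1CCCC1` gives 20700 nM as a measured number. Compound 4 `COc1ccc(-c2noc(-c3ccc(Cl)cc3)n2)cc1OC1CCCC1` departs from compound 1 thus: 4-chlorophenyl in place of pyridin-4-yl on an aromatic carbon with 4-chlorophenyl in place of pyridin-4-yl on an aromatic carbon. The closest measured change is 4-fluorophenyl in place of pyridin-4-yl, which gives an at least 48-fold lower number from compound 1 to compound 2 (1.68 log units; beyond the scatter) as a large step. Pyridin-3-yl in place of 4-fluorophenyl gives an at least 48-fold higher number from compound 2 to compound 3 (1.68 log units; beyond the scatter) as a large step back, while a step that the two limits leave unreadable from compound 1 to compound 3 stays unreadable. Following compound 2, the expected outcome in this assay is a large fall, an estimated at least 50-fold lower number from compound 1 to compound 4 (1.69 log units; beyond the scatter) toward a lower number. The estimated value for compound 4 is 20000 nM with an expected range of 7000 nM to 60000 nM for now.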

Compound 4, half-maximal inhibitory concentration: 123000 nM
Compound 4: middle estimate off by 6.2-fold (0.79 log units), on the low side, and the stated range ends below it.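

In this assay, the gain on replacing a pyridinyl group is not confined to 4-fluorophenyl: 4-chlorophenyl gives an at least 8.1-fold lower number from compound 1 to compound 4 (0.91 log units; beyond the scatter) and an at least 8.1-fold lower number from compound 3 to compound 4 (0.91 log units; beyond the scatter). The halogen also counts at this position, since chloro in place of fluoro gives a 5.9-fold higher number from compound 2 to compound 4 (0.77 log units; beyond the scatter). The two steps from the pyridinyl compounds give only a minimum size because each starts from a limit: the limit of > 1000000 nM in this assay, at which 2 of the 4 values shown sit.

Still open, on these data alone, is how plain phenyl, without a halogen, compares at this position. Also open, as far as these compounds go, is whether 4-bromophenyl or 4-methoxyphenyl sits closer to 4-fluorophenyl or to 4-chlorophenyl.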